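A few compounds are considered here, and "the series" means these few. Any claim that something is new, unique, unknown or untested is made for them only; others in the source may bear on it.

Going by the values given here, compound 2 `NC(=O)c1ccc2c(c1)CCOC2CCN1CC=C(c2c[nH]c3cc(Cl)ccc23)CC1` gives 145 nM in an assay on cells for binding affinity to 5-hydroxytryptamine receptor 1D (Homo sapiens), read by radioligand binding (a lower number here means a stronger inhibitor, a higher number a weaker inhibitor), which is the higher of the two numbers measured so far. Its nearest neighbour, compound 1 `NC(=O)c1ccc2c(c1)CCOC2CCN1CC=C(c2cccc3ccccc23)CC1`, gives 5.4 nM in this assay, and the two are separated by a 27-fold higher number from compound 1 to compound 2 (1.43 log units; beyond the scatter), a step that came from placing a 6-chloro-1H-indol-3-yl group instead of naphthalen-1-yl on the double-bonded ring carbon.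

Compound 3 `NC(=O)c1ccc2c(c1)CCOC2CCN1CC=C(c2c[nH]c3cc(C(F)(F)F)ccc23)CC1` has not yet been measured. It differs from compound 2 in one place: trifluoromethyl in place of chloro on an aromatic carbon. Among the compounds with values here, none of the measured steps swaps these two groups for one another, and the single step that is known, a 27-fold higher number from compound 1 to compound 2 (1.43 log units; beyond the scatter), concerns a different exchange at a different place, so it offers no direct guide to the size or direction of the present change. With nothing in the measured pair pointing to a change beyond the scatter, the expected step in this assay is small, no change at the digits printed from compound 2 to compound 3 (within the scatter). Compound 3 is therefore estimated at 145 nM, with a range from 45 nM to 470 nM.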

Compound 3, inhibition constant: 122 nM
The estimate for compound 3 lay 1.2-fold (0.08 log units) above the measured number, within the range that was stated.
By their numbers in this assay, from the lowest: compound 1; then compounds 3 and 2 (each within the scatter of the next).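

In this assay the exchange of chloro for trifluoromethyl on this aromatic carbon gives a 1.2-fold lower number from compound 2 to compound 3 (0.08 log units; within the scatter) and so leaves the two compounds indistinguishable, even though the group entering has 4 heavy atoms and the group leaving has 1 heavy atom. Going by these compounds alone, this is the first look at this position, and it shows that these two groups can stand in for each other here without a reading beyond the scatter. Within the data shown here, the only other step available, a 27-fold higher number from compound 1 to compound 2 (1.43 log units; beyond the scatter), replaced the whole group on the double-bonded ring carbon, so that large step and this small one concern different places; nothing here explains why chloro and trifluoromethyl read alike.

With only these two groups shown on this carbon, it remains open whether a plain hydrogen, a methoxy group, an amine or a carboxylic acid there would also stay within the scatter of compound 2 or move the number well away from it. From the compounds shown here alone, it is also open whether the same exchange would read alike on another carbon of this six-membered aromatic ring.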